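Amide variation in the series: expectation for compound 4

This account rests on a few compounds, and the source may have more. Where it says the series, first, only, none or still open, it means among the compounds named here.

Measured compounds:
Compound 1, `CCN(CC)S(=O)(=O)c1ccc(S(=O)(=O)N2CCC[C@@H](C(=O)N3CCS(=O)(=O)CC3)C2)cc1`: in a functional assay on MIA PaCa-2 cells (Homo sapiens) for inhibition, read by MTT assay, with a stated time of 3 days (a lower number here means a stronger inhibitor, a higher number a weaker inhibitor), compound 1 gives > 10000 nM, which is a limit of the assay and not a number.
Compound 2, `CCN(CC)S(=O)(=O)c1ccc(S(=O)(=O)N2CCC[C@@H](C(=O)N3CCOCC3)C2)cc1`: in this assay compound 2 gives > 10000 nM, again a limit.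
Compound 3, `CCN(CC)S(=O)(=O)c1ccc(S(=O)(=O)N2CCC[C@@H](C(=O)N3CC[C@@H](OC)C3)C2)cc1`: in this assay compound 3 gives > 10000 nM, again a limit.

Compound 3 thus stands at the limit, and so do the other two measured compounds; all three sit at the limit of > 10000 nM in this assay, at which 3 of the 3 values shown sit. The steps among them, a step that the two limits leave unreadable from compound 1 to compound 2, a step that the two limits leave unreadable from compound 1 to compound 3 and a step that the two limits leave unreadable from compound 2 to compound 3, are all left unreadable by the limits, so none of them has a known size or direction.

Compound 4, `CCN(CC)S(=O)(=O)c1ccc(S(=O)(=O)N2CCC[C@@H](C(=O)N[C@@H]3CCOC3)C2)cc1`, differs from compound 3 in one place: (oxolan-3-yl)amino in place of 3-methoxypyrrolidin-1-yl on a carbonyl carbon. The three measured steps bear on this change in that each earlier exchange of the group on the carbonyl carbon left the value at the limit, but none of them yields a readable size, so no direction can be taken from them. The expectation is therefore that compound 4 in this assay again returns a limit rather than a number, and the step from compound 3 to compound 4 is expected at a step that the limit leaves unreadable from compound 3 to compound 4. The estimate for compound 4 is 20000 nM, in a range from 5000 nM to 80000 nM.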

Compound 4, half-maximal inhibitory concentration: > 10000 nM
Compound 4 ended at the assay's limit; the forecaster's own chance of this, stated with the estimate: 85%; the middle value lies beyond the limit too.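

In this assay compound 4 gives > 10000 nM, which is a limit and not a number. The steps to compound 4 from compound 1, compound 2 and compound 3 therefore cannot be read, in size or in direction.

The compounds shown leave open whether any group on this carbonyl carbon gives a measurable value, because all of them stand at one limit: the limit of > 10000 nM in this assay, at which 4 of the 4 values shown sit.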